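The compounds below may be only part of what the source reports. "The series", "measured", "known", "first", "only" and "open" are said of these compounds alone.

Series notes, cytotoxic read-out. For the measured compounds named here, compound 2 `COc1cc(N2C(N)=C(C#N)C(c3c(O)ccc4ccccc34)C3=C2CC(C)(C)CC3=O)cc(OC)c1OC` is the lower of the two compounds measured so far: in a functional assay on Ehrlich cells (Mus musculus) for cytotoxicity, tested at 50 ug/mL (a lower number here means a weaker effect, a higher number a stronger effect of the compound at the concentration tested), compound 2 gives 15%, while compound 1 `COc1cc(N2C(N)=C(C#N)C(/C=C/c3ccccc3)C3=C2CC(C)(C)CC3=O)cc(OC)c1OC` in the same read-out gives 30%. Going by the values given here, the only step available, a number 15 percentage points lower from compound 1 to compound 2 (beyond the scatter), arose from the exchange of 2-phenylethenyl for 2-hydroxynaphthalen-1-yl on the saturated ring carbon, and no other pair of measured compounds exists.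

Compound 3 `COc1cc(N2C(N)=C(C#N)C(c3ccc(Cl)cc3Cl)C3=C2CC(C)(C)CC3=O)cc(OC)c1OC` is the next member, not yet measured in this assay. 2,4-dichlorophenyl in place of 2-hydroxynaphthalen-1-yl on a saturated ring carbon It touches the same saturated ring carbon as the measured step, but neither the group that leaves in that step nor the one that enters here has a measured partner, so the measured step bears on the change only by its location and by its modest size. The expectation is therefore a small movement, most likely upward toward the level of compound 1, with the possibility of no change beyond the scatter. For compound 3 the estimate in this assay is 25%, with a range from 10% to 45%, which means an expected step of a number 10 percentage points higher from compound 2 to compound 3 (within the scatter).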

Compound 3, a percentage reported as activity, at one concentration (the size of the read-out at that concentration, not a potency): 95%
For compound 3 the middle estimate is 70 percentage points below the measured one; the measured number lies above the stated range.
By their numbers in this assay, from the lowest: compound 2; then compound 1; then compound 3.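

In this assay, the saturated ring carbon proves far more sensitive than the first step indicated: 2,4-dichlorophenyl in place of 2-hydroxynaphthalen-1-yl gives a number 80 percentage points higher from compound 2 to compound 3 (beyond the scatter), and the same group in place of 2-phenylethenyl gives a number 65 percentage points higher from compound 1 to compound 3 (beyond the scatter). Compound 3 therefore stands clearly above both earlier compounds, and the position can move the read-out over a large part of its scale while the rest of the core stays fixed. Nothing measured explains the size of this rise, and the change alters the ring count, the donor and acceptor counts and the presence of chlorine together, so these features cannot be separated.

The compounds shown leave open whether the gain belongs to the chlorine atoms or to the single phenyl ring, which plain phenyl, a monochlorophenyl or a dimethoxyphenyl at this carbon would help to separate. They also leave open how far the high value depends on the 3,4,5-trimethoxyphenyl group on the ring nitrogen, since all of them carry it and a comparison with plain phenyl or a 4-chlorophenyl there is absent from this set.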